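Hydrogen in place of chloro: outlook for clearance

A few compounds are considered here, and "the series" means these few. Any claim that something is new, unique, unknown or untested is made for them only; others in the source may bear on it.

Working notes on a small set sharing one core. Compound 1 `CC(C)c1c(COc2cccc(OCC3CCOCC3)c2)[nH]c2ccccc2c1=O` has no result in an in vitro ADME assay on microsomes from liver (Homo sapiens) for metabolic stability, tested at 0.2 uM; a lower number here means slower removal, a higher number faster removal of the compound; its entry reads "not determined" (no result reported). Compound 2 `Cc1c(COc2cccc(OCC3CCOCC3)c2)[nH]c2ccc(Cl)cc2c1=O` in this assay gives > 1000 mL/min/kg, which is a limit of the assay and not a number. Among the values shown, compound 2 therefore stands at the limit of > 1000 mL/min/kg in this assay, at which 1 of the 2 values shown sits, so its true position is open upward and only the floor of its clearance is known.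

Compound 3 `Cc1c(COc2cccc(OCC3CCOCC3)c2)[nH]c2ccccc2c1=O` is the next entry to be measured. It differs from compound 2 in one place: hydrogen in place of chloro on an aromatic carbon. Among the measured compounds shown here, no step between two measured compounds is available here, so no measured change can be drawn on for this exchange.

Expectation rests on compound 2 alone. Since compound 2 sits at the limit of > 1000 mL/min/kg in this assay, at which 1 of the 2 values shown sits, compound 3 is expected to remain in the high-clearance region, with the step from compound 2 estimated as an at least 1.2-fold lower number from compound 2 to compound 3 (0.09 log units; that floor lies within the scatter), either none beyond the scatter or a modest move downward. Compound 3 is accordingly estimated at 800 mL/min/kg in this assay, with a range from 300 mL/min/kg to 1500 mL/min/kg.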

Compound 3, clearance: 214 mL/min/kg
Estimate against measurement, compound 3: 3.7-fold (0.57 log units) above, outside the stated range (below it).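

In this assay, hydrogen in place of chloro on this aromatic carbon, meta to a fused ring and para to a fused ring, gives an at least 4.6-fold lower number from compound 2 to compound 3 (0.66 log units; beyond the scatter). This position therefore matters for clearance in the series: a single exchange on the shared core, with the tetrahydropyranyl methoxy side and the methyl group left unchanged, leaves compound 3 with a readable number, 214 mL/min/kg. The true size of the step stays unknown, and the printed figure is only a floor, because compound 2 is held at a limit of the assay and not a number: the limit of > 1000 mL/min/kg in this assay, at which 1 of the 3 values shown sits.

The values shown do not say why clearance differs between the two compounds, nor whether another group on this carbon, such as fluoro, methoxy or nitrile, would read closer to compound 3 or to compound 2. Steps involving compound 1 cannot be read, as its entry holds no result, so the effect of the larger alkyl group on the core remains open as well.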